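The source may hold more compounds than are shown below. What is called first, only, known or untested is meant among the compounds shown, and "the series" means these compounds.

Measured so far in a functional assay on HUVEC cells (Homo sapiens) for inhibition, tested at 5 ug/mL; on this read-out higher numbers stand for a stronger effect at the one concentration tested and lower numbers for a weaker effect:
- compound 1, `COc1cc(/C=C/C(=O)c2cccc(NC(=O)c3ccco3)c2)ccc1O`, gives 82%
- compound 2, `COc1cc(/C=C/C(=O)c2cccc(NC(=O)c3ccccc3)c2)ccc1O`, gives 48%
- compound 3, `COc1cc(/C=C/C(=O)c2cccc(NC(=O)c3cccs3)c2)ccc1O`, gives 80%

Compound 3 stands second highest of the three. Its nearest neighbour is compound 1: the step of a number 2 percentage points lower from compound 1 to compound 3 (within the scatter) is within the scatter, so the two cannot be ordered. Its furthest is compound 2: the step of a number 32 percentage points higher from compound 2 to compound 3 (beyond the scatter) is large and beyond the scatter.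

Compound 4 is `COc1cc(/C=C/C(=O)c2cccc(NC(=O)c3ccc(Cl)cc3)c2)ccc1O`. The change from compound 3 is 4-chlorophenyl in place of thiophen-2-yl on a carbonyl carbon.

Among the compounds with values here, two measured steps bear on it, both at the same carbonyl carbon. The step of a number 34 percentage points lower from compound 1 to compound 2 (beyond the scatter) and the step of a number 32 percentage points higher from compound 2 to compound 3 (beyond the scatter) both show that the six-membered carbon-only ring goes with a much lower number in this assay than either five-membered ring with one hetero atom. Within the data shown here, compound 4 carries 4-chlorophenyl rather than plain phenyl; no measured compound shows what the chlorine adds, so the expectation rests on the phenyl steps alone. A drop beyond the scatter is therefore expected, of the order of a number 30 percentage points lower from compound 3 to compound 4 (beyond the scatter), with added uncertainty for the chlorine. Compound 4 is estimated at 50%, between 30% and 72%.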

Compound 4, a percentage reported as inhibition, at one concentration (the size of the read-out at that concentration, not a potency): 42%
Compound 4: the middle estimate sits 8 percentage points above what was measured; measured number inside the range.
By their numbers in this assay, from the lowest: compounds 4 and 2 (each within the scatter of the next); then compounds 3 and 1 (each within the scatter of the next).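

The step of a number 6 percentage points lower from compound 2 to compound 4 (within the scatter) in this assay shows that chloro in place of hydrogen on an aromatic carbon gives no readable change in the phenyl amide. The low standing of the six-membered carbon-only ring therefore holds with the chlorine present, as the steps of a number 38 percentage points lower from compound 3 to compound 4 (beyond the scatter) and a number 40 percentage points lower from compound 1 to compound 4 (beyond the scatter) show for 4-chlorophenyl against thiophen-2-yl and furan-2-yl. On this carbonyl carbon the four compounds fall into two groups, compounds 1 and 3 with the five-membered rings and compounds 2 and 4 with the six-membered rings, and none of the four goes against this split.

No measurement offered here explains the split.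
Still open, going by these compounds, is whether a pyridin-3-yl ring on this carbonyl carbon would fall with the six-membered rings or the five-membered rings. On these data alone, a saturated cyclopentyl ring or a short alkyl chain in this place is equally open.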